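A few compounds are considered here, and "the series" means these few. Any claim that something is new, unique, unknown or untested is made for them only; others in the source may bear on it.

Compound 3 `Cc1ccc(-c2cnc(C)n2C)cc1NC(=O)c1ccc(OCc2ccccn2)cc1` gives the highest of the three solubility numbers: in a physicochemical assay for solubility, at pH 7.4 (a lower number here means a less soluble compound, a higher number a more soluble compound), compound 3 gives 371000 nM. Compound 2 `Cc1ccc(-c2nccn2C)cc1NC(=O)c1ccc(OCc2ccccn2)cc1` stands nearest, giving 192000 nM in this assay, and the step of a 1.9-fold higher number from compound 2 to compound 3 (0.29 log units; within the scatter) is within the scatter. Compound 1 `Cc1cc(Cl)c(-c2cn(C)cn2)cc1NC(=O)c1ccc(OCc2ccccn2)cc1` lies furthest, with 20000 nM in this assay, a gap beyond the scatter. Compound 4 `Cc1ccc(-c2c[nH]cn2)cc1NC(=O)c1ccc(OCc2ccccn2)cc1` differs from compound 3 by 1H-imidazol-4-yl in place of 1,2-dimethyl-1H-imidazol-5-yl on an aromatic carbon. Going by the values given here, the only measured step that alters the five-membered aromatic ring, between compound 2 and compound 3, stayed within the scatter, and no measured step covers this particular change. Compound 4 is therefore expected to show no step beyond the scatter, a 1.2-fold lower number from compound 3 to compound 4 (0.09 log units; within the scatter). Compound 4 is estimated at 300000 nM, within a range from 100000 nM to 900000 nM.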

Compound 4, solubility: 90000 nM
For compound 4 the middle estimate is 3.3-fold (0.52 log units) above the measured one, and the stated range ends above it.
By their numbers in this assay, from the lowest: compound 1; then compound 4; then compounds 2 and 3 (each within the scatter of the next).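

Altering the five-membered aromatic ring at this position can move the number in this assay beyond the scatter: 1H-imidazol-4-yl in place of 1,2-dimethyl-1H-imidazol-5-yl gives a 4.1-fold lower number from compound 3 to compound 4 (0.62 log units; beyond the scatter) and, in place of 1-methyl-1H-imidazol-2-yl, gives a 2.1-fold lower number from compound 2 to compound 4 (0.33 log units; beyond the scatter) in the same direction. The entering ring is the smaller one and has 1 hydrogen-bond donor. Nothing available here explains the drop.

The compounds shown leave open how far removing the methyl groups and changing the ring's point of attachment each contribute. They also leave open how a ring bearing an amine or a carboxylic acid would read at this position.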